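This account rests on a few compounds, and the source may have more. Where it says the series, first, only, none or still open, it means among the compounds named here.

Measured compounds in a functional assay on HOS cells (Homo sapiens) for antiproliferative activity; on this read-out lower numbers stand for stronger inhibition and higher numbers for weaker inhibition:

Compound 1, `Nc1n[nH]c(N)c1/N=N/c1ccccc1[N+](=O)[O-]`, gives > 100000 nM, which is a limit of the assay and not a number.
Compound 2, `Nc1n[nH]c(N)c1/N=N/c1cccc([N+](=O)[O-])c1`, gives > 100000 nM, likewise a limit of the assay.
Compound 3, `Nc1n[nH]c(N)c1/N=N/c1ccccc1O`, gives > 100000 nM, again a limit of the assay.

All three values sit at the same boundary, so none of the three compounds can be set in order against the others. Compound 1 and compound 3 differ in one place: hydroxy in place of nitro on an aromatic carbon. The step that this change makes, a step that the two limits leave unreadable from compound 1 to compound 3, cannot be read, since both values are limits. Compound 2 has the same atoms as compound 1, joined differently; the difference between the two cores is not broken down here.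

Compound 4, `Nc1n[nH]c(N)c1/N=N/c1cccc(O)c1`, has not yet been measured. It differs from compound 2 by hydroxy in place of nitro on an aromatic carbon. Going by the values given here, this is the same kind of change as the one from compound 1 to compound 3, but not the same: in compound 3 the hydroxy stands ortho to a group of 9 heavy atoms, in compound 4 meta to a group of 9 heavy atoms.

Among the compounds with values here, the step expected from compound 2 to compound 4 in this assay is a step that the limit leaves unreadable from compound 2 to compound 4, set beside the unreadable earlier step; this expectation rests on (the limit of > 100000 nM in this assay, at which 3 of the 3 values shown sit), where every value so far sits. For compound 4 the estimate is 150000 nM, with an expected range from 50000 nM to 500000 nM, and the most likely outcome is that only a limit is reported once more.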

Compound 4, half-maximal inhibitory concentration: > 100000 nM
Compound 4 gave a limit, no number; the forecaster's own chance of this, stated with the estimate: 85%; the middle value is on the limit's open side.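

Going by these compounds alone, compound 2 and compound 4 both stand at a limit of the assay rather than at a number, so the step between them cannot be read, and no new step emerges. The compounds shown leave open how hydroxy and nitro compare on this shared core, and which change to it, if any, would give a readable number, since every result so far is the same boundary: the limit of > 100000 nM in this assay, at which 4 of the 4 values shown sit.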